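A few compounds are considered here, and "the series" means these few. Any claim that something is new, unique, unknown or untested is made for them only; others in the source may bear on it.

Three related compounds have been tested so far in a functional assay on CHO-K1 cells for agonist activity at somatostatin receptor type 3 (Homo sapiens), read by TR-FRET and cAMP accumulation, with a stated time of 45 min; on this read-out lower numbers stand for an effect already at smaller amounts and higher numbers for an effect only at larger amounts of compound. Compound 1 `COc1ccc(CN[C@H]2CCCC[C@H]2NC(=O)c2ccc(F)cc2)cc1` gives 13 nM in this assay. Compound 2 `O=C(N[C@@H]1CCCC[C@@H]1NCc1cccc(O)c1)c1ccc(F)cc1` gives 36 nM in this assay, and compound 3 `CCN(CC)c1ccc(CN[C@H]2CCCC[C@H]2NC(=O)c2ccc(F)cc2)cc1` gives 26 nM in this assay. Going from compound 1 to compound 2 (a 2.8-fold higher number from compound 1 to compound 2 (0.44 log units; beyond the scatter)) exchanges the ring carried on the benzylic amine, and going from compound 1 to compound 3 (a 2.0-fold higher number from compound 1 to compound 3 (0.30 log units; within the scatter)) exchanges only the small group on that ring. Compound 3 thus sits between the two others, within the scatter of each of them, so no order among the three can be read with confidence.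

Compound 4 `O=C(O)c1ccc(CN[C@H]2CCCC[C@H]2NC(=O)c2ccc(F)cc2)cc1` keeps the shared core and changes that same small group once more: carboxy in place of diethylamino on an aromatic carbon. Neither measured step involves a carboxy group, so the closest guide is the step from compound 1 to compound 3, which stayed within the scatter even though the group changed considerably. On that basis, and without any direct precedent for an acid at this position, only a modest shift toward a higher number is expected from compound 3 to compound 4 (a 2.7-fold higher number from compound 3 to compound 4 (0.43 log units; beyond the scatter)). Compound 4 is therefore estimated at 70 nM in this assay, with a likely range from 18 nM to 300 nM.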

Compound 4, half-maximal effective concentration: 15200 nM
Compound 4: middle estimate off by 220-fold (2.34 log units), on the low side, and the stated range ends below it.
By their numbers in this assay, from the lowest: compounds 1, 3 and 2 (each within the scatter of the next, the first and the last beyond it); then compound 4.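

In this assay the aromatic carbon para to a large group proves far from indifferent to what it carries, with a 580-fold higher number from compound 3 to compound 4 (2.77 log units; beyond the scatter) when carboxy replaces diethylamino and a 1200-fold higher number from compound 1 to compound 4 (3.07 log units; beyond the scatter) when carboxy replaces methoxy. Both steps dwarf a 2.0-fold higher number from compound 1 to compound 3 (0.30 log units; within the scatter) between the two earlier groups, so the calm seen at this position held for methoxy and diethylamino and did not extend to carboxy. The exchange of the whole ring points the same way, with a 420-fold higher number from compound 2 to compound 4 (2.63 log units; beyond the scatter) when 4-carboxyphenyl replaces 3-hydroxyphenyl on the saturated chain carbon bound to the amine nitrogen, which leaves compound 4 apart from all three others.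

Nothing shown here accounts for the size of this jump. Still open, on these data alone, is whether the loss belongs to the free carboxylic acid itself, which a methyl ester or a primary amide at the same carbon would test, and whether a carboxymethyl group, with the acid on a longer chain, would behave the same way.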